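Working notes: hydroxy in place of trifluoromethyl

The source may hold more compounds than are shown below. What is called first, only, known or untested is meant among the compounds shown, and "the series" means these compounds.

In a functional assay on A549 cells (Homo sapiens) for inhibition, read by CCK-8 assay, with a stated time of 72 h, tested at 10 uM (on this read-out lower numbers stand for less inhibition of growth and higher numbers for more inhibition of growth at the one concentration tested), compound 1 (`COc1cccc(NC(=O)C2(C(=O)Nc3ccc(Nc4ncc5cc(C(=O)N(C)C)n(C6CCCC6)c5n4)cc3)CC2)c1`) gives 96%, compound 2 (`CN(C)C(=O)c1cc2cnc(Nc3ccc(NC(=O)C4(C(=O)Nc5cccc(Br)c5)CC4)cc3)nc2n1C1CCCC1`) gives 92.2% and compound 3 (`CN(C)C(=O)c1cc2cnc(Nc3ccc(NC(=O)C4(C(=O)Nc5ccc(C(F)(F)F)cc5)CC4)cc3)nc2n1C1CCCC1`) gives 87.9%, which places compound 3 within the scatter of both others. Compound 4 (`CN(C)C(=O)c1cc2cnc(Nc3ccc(NC(=O)C4(C(=O)Nc5ccc(O)cc5)CC4)cc3)nc2n1C1CCCC1`) carries hydroxy in place of trifluoromethyl on an aromatic carbon, para to a large group: hydroxy in place of trifluoromethyl on an aromatic carbon. Going by the values given here, three measured steps bear on this change, all within the scatter: a number 8.1 percentage points lower from compound 1 to compound 3 (within the scatter), a number 4.3 percentage points lower from compound 2 to compound 3 (within the scatter) and a number 3.8 percentage points lower from compound 1 to compound 2 (within the scatter). Among the compounds with values here, no measured compound carries hydroxy, so the range stays wide. The expected change is a number 3.9 percentage points lower from compound 3 to compound 4 (within the scatter), with no step beyond the scatter anticipated. The estimated value for compound 4 is 84%, with an expected range of 62% to 96%.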

Compound 4, percent growth inhibition at one concentration: 94.4%
Compound 4: the middle estimate sits 10.4 percentage points below what was measured; measured number inside the range.
By their numbers in this assay, from the lowest: compounds 3, 2, 4 and 1 (each within the scatter of the next).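

In this assay, hydroxy on this aromatic carbon, para to a large group, gives a number 6.5 percentage points higher from compound 3 to compound 4 (within the scatter) as the step from trifluoromethyl, so this position accepts a hydrogen-bond donor and acceptor without a change beyond the scatter. The aryl change on the amide-type nitrogen reads the same way, with a number 2.2 percentage points higher from compound 2 to compound 4 (within the scatter) and a number 1.6 percentage points lower from compound 1 to compound 4 (within the scatter) as its two further steps. No measurement given here accounts for these numbers.

On these data alone, an amine or a carboxylic acid on this carbon remains open. As far as these compounds go, all four compounds lie within the scatter at the one concentration tested, so the size of any effect at this position also remains open.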